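The source may report more compounds than this note shows. Statements on the series, on what has been measured and on what is new or still open speak of the compounds shown alone.

Measured so far:
compound 1, `CC(=O)N1N=C(c2ccc(N3CCN(C)CC3)cc2)CC1c1ccc(N(C)C)cc1` — -0.8%
compound 2, `CN1CCN(c2ccc(C3=NN(C(=O)c4ccc(F)cc4)C(c4ccc(N(C)C)cc4)C3)cc2)CC1` — 31.8%

For the measured compounds named here, in a functional assay on HCC1806 cells (Homo sapiens) for inhibition, read by sulforhodamine B assay, tested at 10 uM (on this read-out higher numbers stand for more inhibition at the one concentration tested (going by the name of the read-out) and lower numbers for less inhibition), compound 2 stands highest of the two numbers; the nearest is compound 1, a number 32.6 percentage points higher from compound 1 to compound 2 (beyond the scatter), which is the only measured step and concerns the group on the carbonyl carbon. Compound 3, `CN1CCN(c2ccc(C3=NN(C(=O)c4ccc(C(F)(F)F)cc4)C(c4ccc(N(C)C)cc4)C3)cc2)CC1`, differs from compound 2 by trifluoromethyl in place of fluoro on an aromatic carbon. Going by the values given here, no measured step alters a substituent on this ring, so the single step from compound 1 to compound 2 bears on the present change only in that it shows the aryl group on the carbonyl carbon matters for this assay. Among the compounds with values here, with no direct precedent, compound 3 is expected to stay near compound 2, with a step of about a number 6.2 percentage points higher from compound 2 to compound 3 (within the scatter) that may not exceed the scatter. The estimate for compound 3 is 38%, within 15% to 62%.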

Compound 3, a percentage reported as inhibition, at one concentration (the size of the read-out at that concentration, not a potency): 84.1%
The estimate for compound 3 lay 46.1 percentage points below the measured number, outside the stated range (above it).
By their numbers in this assay, from the lowest: compound 1; then compound 2; then compound 3.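

In this assay, the substituent para to a large group on the aryl ring of the aroyl group proves to be a strong determinant of the read-out, a point the earlier pair could not address: trifluoromethyl in place of fluoro gives a number 52.3 percentage points higher from compound 2 to compound 3 (beyond the scatter) on an otherwise unchanged structure. Against the acetyl end of the series, 4-(trifluoromethyl)phenyl in place of methyl on the carbonyl carbon gives a number 84.9 percentage points higher from compound 1 to compound 3 (beyond the scatter), so the presence of an aryl group on the carbonyl carbon does not alone set the level reached. The data at hand offer no measurement that accounts for the size of this step.

Open, on these data alone, is whether the gain is specific to trifluoromethyl, since a chloro, methoxy or nitrile group at this place, or an unsubstituted phenyl, would test that. Also open, as far as these compounds go, is whether the same substituent effect holds at other concentrations, as the read-out here comes from a single one.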